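Sulfonamide nitrogen aryl swap in an EP1 antagonist series

A few compounds are considered here, and "the series" means these few. Any claim that something is new, unique, unknown or untested is made for them only; others in the source may bear on it.

Measured so far:
compound 1, `CCc1ccccc1N(CC(=O)NCc1ccc(Cl)cc1)S(=O)(=O)c1ccc(C)cc1`, 11.5 nM
compound 2, `CCc1ccccc1N(CC(=O)NCc1ccccc1F)S(=O)(=O)c1ccc(C)cc1`, 135 nM
compound 3, `CCc1ccccc1N(CC(=O)NCc1ccccc1OC)S(=O)(=O)c1ccc(C)cc1`, 1070 nM

In a functional assay on CHO-K1 cells for antagonist activity at prostaglandin E2 receptor EP1 subtype (Homo sapiens), read by FLIPR and calcium flux (on this read-out higher numbers stand for weaker inhibition and lower numbers for stronger inhibition), compound 1 holds the lowest of the three numbers. Its nearest neighbour is compound 2, with a 12-fold higher number from compound 1 to compound 2 (1.07 log units; beyond the scatter), and the furthest is compound 3, with a 93-fold higher number from compound 1 to compound 3 (1.97 log units; beyond the scatter); between those two the step is a 7.9-fold higher number from compound 2 to compound 3 (0.90 log units; beyond the scatter). All three steps are beyond the scatter, so compound 1 is the strongest inhibitor shown.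

Compound 4, `Cc1ccc(S(=O)(=O)N(CC(=O)NCc2ccc(Cl)cc2)c2ccnn2C)cc1`, keeps everything of compound 1 except (1-methyl-1H-pyrazol-5-yl in place of 2-ethylphenyl on a sulfonamide nitrogen). Among the measured compounds shown here, none of the measured steps touches the sulfonamide nitrogen: each of them changes only the aryl group carried on the amide side, and so none bears directly on this change. What they show is that the series as a whole is sensitive to aryl replacements, with losses of the order seen from compound 1 to compound 2 and compound 3. For the measured compounds named here, for the exchange of 2-ethylphenyl for 1-methyl-1H-pyrazol-5-yl there is no precedent among the numbers, and the expectation is therefore a modest weakening with wide uncertainty, a 3.5-fold higher number from compound 1 to compound 4 (0.54 log units; beyond the scatter), rather than a gain. Compound 4 is estimated at 40 nM in this assay, within 8 nM to 250 nM.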

Compound 4, inhibition constant: 589 nM
Compound 4: the middle estimate sits 15-fold (1.17 log units) below what was measured; the measured number lies above the stated range.
By their numbers in this assay, from the lowest: compound 1; then compound 2; then compounds 4 and 3 (each within the scatter of the next).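

In this assay the sulfonamide nitrogen proves to be a position that responds strongly to the group it carries: 1-methyl-1H-pyrazol-5-yl in place of 2-ethylphenyl gives a 51-fold higher number from compound 1 to compound 4 (1.71 log units; beyond the scatter) with the 4-chlorophenyl on the amide side held constant. Among the compounds shown here, the earlier steps varied only the aryl group on the amide side, so this is the first sign that the series also depends on the group on the sulfonamide nitrogen, and this exchange of a six-membered carbon ring for a five-membered ring with 2 hetero atoms is poorly tolerated. Nothing available explains the loss, and the ring, the hetero atoms and the absence of the ethyl group cannot be told apart as its source.

Going by these compounds, whether an unsubstituted phenyl, a 2-methylphenyl or a pyridine on the sulfonamide nitrogen would keep the number of compound 1 stays open, and so does the question of whether the ethyl group or the six-membered ring matters more. Also open, on these data alone, is whether the same exchange costs as much with another aryl group on the amide side, such as the 2-fluorophenyl of compound 2.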